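Anilide series: sulfamoylphenyl in place of chlorophenyl

A few compounds are considered here, and "the series" means these few. Any claim that something is new, unique, unknown or untested is made for them only; others in the source may bear on it.

In a functional assay (Homo sapiens) for inhibition, using a membrane potential dye, in the presence of a further agent that is not named here (a lower number here means a stronger inhibitor, a higher number a weaker inhibitor), compound 1 `COc1ccc(Oc2ccc([N+](=O)[O-])cc2C(=O)Nc2ccc(Cl)cc2)cc1` gives 10100 nM, the higher of the two numbers recorded so far. Within the data shown here, compound 2 `CC1(NC2=NS(=O)(=O)c3sc(Cl)cc3N2)CC1` gives 600 nM in this assay, a gap that lies beyond the usual scatter; the two structures are not related by a single exchange, so no step is drawn between them. Compound 3 `COc1ccc(Oc2ccc([N+](=O)[O-])cc2C(=O)Nc2cccc(S(N)(=O)=O)c2)cc1` differs from compound 1 by 3-sulfamoylphenyl in place of 4-chlorophenyl on an amide-type nitrogen. No comparable exchange has been measured, so the direction is open; the expected step is a 1.3-fold lower number from compound 1 to compound 3 (0.10 log units; within the scatter), probably within the scatter. For compound 3 the estimate is 8000 nM, with a range from 2000 nM to 30000 nM.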

Compound 3, half-maximal inhibitory concentration: 9900 nM
Compound 3: middle estimate off by 1.2-fold (0.09 log units), on the low side; low and high end bracket the measured number.
By their numbers in this assay, from the lowest: compound 2; then compounds 3 and 1 (each within the scatter of the next).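

In this assay, 3-sulfamoylphenyl in place of 4-chlorophenyl on the amide-type nitrogen gives a 1.0-fold lower number from compound 1 to compound 3 (0.01 log units; within the scatter), so the two groups read level at this position. At this position, then, the added hydrogen-bond donor and acceptors go with no shift in the number beyond the scatter. No supporting data bear on this result.

As far as these compounds go, whether a carboxylic acid or an amine on this phenyl ring would also read level remains open. So does whether any group at this position can bring the series near compound 2 at 600 nM.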